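Swapping one halogen for another in a thiosemicarbazone

This account rests on a few compounds, and the source may have more. Where it says the series, first, only, none or still open, it means among the compounds named here.

Compound 2, `NC(=S)N/N=C/c1ccccc1Cl`, gives 200000 nM in a functional assay on Molt4/C8 cells (Homo sapiens) for cytotoxicity; a higher number here means a weaker inhibitor, a lower number a stronger inhibitor. Compound 1, `Oc1ccccc1/C=N/c1ccc(F)c(Cl)c1`, gives 112000 nM in this assay, and the two numbers lie within the usual scatter of each other, so neither compound can be set apart from the other. Compound 3, `NC(=S)N/N=C/c1ccccc1F`, carries fluoro in place of chloro on an aromatic carbon. Among the measured compounds shown here, no measured pair shows what this swap does here, so no step beyond the scatter is expected in this assay in either direction, and the expected step is no change at the digits printed from compound 2 to compound 3 (within the scatter). Compound 3 is therefore estimated at 200000 nM, within 80000 nM to 500000 nM.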

Compound 3, half-maximal inhibitory concentration: 140000 nM
Compound 3: middle estimate off by 1.4-fold (0.15 log units), on the high side; the measured number falls inside the stated range.
By their numbers in this assay, from the lowest: compounds 1, 3 and 2 (each within the scatter of the next).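

Among the compounds shown here, for the first time, two compounds here differ in one place only. In this assay, fluoro in place of chloro on this aromatic carbon gives a 1.4-fold lower number from compound 2 to compound 3 (0.15 log units; within the scatter), so at this position the two halogens cannot be told apart. No measurement shown here offers an explanation for this result. As far as these compounds go, what remains open is whether a group other than a halogen in this same place, such as an amine or a carboxylic acid, would give a step beyond the scatter. The compounds shown also leave open how a methoxy group would read there.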